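From a Chain Amine to a Ring-Bound Amine

The source may report more compounds than this note shows. Statements on the series, on what has been measured and on what is new or still open speak of the compounds shown alone.

Of the compounds shown here, three sharing one core have been tested in a functional assay on Umbilical vein for antagonist activity at B1 bradykinin receptor (Homo sapiens), using Schild analysis, with a stated time of 30 min; on this read-out lower numbers stand for lower potency and higher numbers for higher potency (the scale is a negative logarithm). Compound 1 `COc1cc(C)c(S(=O)(=O)N(C)CCOCC(=O)N2CCN(CCN(C)C)CC2)c(C)c1` gives 7.4. Compound 2 `COc1cc(C)c(S(=O)(=O)N(C)CCOCC(=O)N2CCN(C3CCN(C4CC4)CC3)CC2)c(C)c1` gives 8.5. Compound 3 `COc1cc(C)c(S(=O)(=O)N(C)CCOCC(=O)N2CCN(CCCN(C)C)CC2)c(C)c1` gives 7.9, the second highest of the three numbers: it stands a number 0.50 log units higher from compound 1 to compound 3 (beyond the scatter) and a number 0.60 log units lower from compound 2 to compound 3 (beyond the scatter).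

Compound 4 `COc1cc(C)c(S(=O)(=O)N(C)CCOCC(=O)N2CCN([C@H]3CN4CCC3CC4)CC2)c(C)c1` has not yet been measured. It differs from compound 3 in one place: a group of 8 heavy atoms (7 carbon, 1 nitrogen; 2 six-membered non-aromatic rings with 1 hetero atom each) in place of a group of 6 heavy atoms (5 carbon, 1 nitrogen; no ring), on an amine nitrogen in a ring. The measured step that bears most on this is the one in which a chain carrying an amine gave way to a ring carrying one, a number 1.10 log units higher from compound 1 to compound 2 (beyond the scatter); the move back to a chain, a number 0.60 log units lower from compound 2 to compound 3 (beyond the scatter), went the other way. Both suggest a gain when the amine sits in a ring. Among the measured compounds shown here, the group entering compound 4 is not the same as the one in compound 2, so a somewhat smaller gain is expected here. Compound 4 is therefore expected to reach about 8.4 in this assay, within a range from 7.8 to 9. That estimate means an expected step of a number 0.50 log units higher from compound 3 to compound 4 (beyond the scatter).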

Compound 4, negative logarithm of the antagonist equilibrium constant: 7.2
Estimate against measurement, compound 4: 1.20 log units above, outside the stated range (below it).
By their numbers in this assay, from the lowest: compounds 4 and 1 (each within the scatter of the next); then compound 3; then compound 2.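

The ring alone does not bring the gain: with the two-ring group on the amine nitrogen, the step is a number 0.70 log units lower from compound 3 to compound 4 (beyond the scatter), so here a ring-bound amine falls short of the open 3-(dimethylamino)propyl chain. Compound 2 and compound 4 both hold their amine in a ring, yet the step is a number 1.30 log units lower from compound 2 to compound 4 (beyond the scatter), which shows that the particular ring group matters at this position, not just the choice of ring over chain. The step to the shorter chain is a number 0.20 log units lower from compound 1 to compound 4 (within the scatter), so the two-ring group and 2-(dimethylamino)ethyl cannot be told apart here.

From the compounds shown here alone, it remains open whether a piperidin-4-yl group with a methyl in place of the cyclopropyl would keep the level of compound 2, or how the opposite arrangement at the defined stereocentre of compound 4 would read. No measurement shown here accounts for the gap between the two ring groups.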